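Swapping Trifluoromethyl for Methoxy on a Weakly Active Core

The source may report more compounds than this note shows. Statements on the series, on what has been measured and on what is new or still open speak of the compounds shown alone.

Compound 1 `O=C(/C=C\Nc1ccc(F)cc1)c1nc(-c2ccc(C(F)(F)F)cc2)n2ccccc12` was tested for its ability to kill a mouse melanoma cell line in a functional assay on B16-F10 cells (Mus musculus) for cytotoxicity, read by MTT assay, with a stated time of 48 h; a lower number here means a stronger inhibitor, a higher number a weaker inhibitor. In this assay compound 1 gives > 30000 nM, which is a limit of the assay rather than a measured number. Compound 2 `COc1ccc(N/C=C\C(=O)c2nc(-c3ccc(F)cc3)n3ccccc23)cc1OC` shares the same core, and in this assay compound 2 gives > 30000 nM, again only a limit. Compound 3 `O=C(/C=C\Nc1cnc2ccccc2c1)c1nc(-c2ccc(C(F)(F)F)cc2)n2ccccc12`, which carries quinolin-3-yl in place of 4-fluorophenyl on the amine nitrogen, in this assay gives > 30000 nM, also a limit. The step that the two limits leave unreadable from compound 1 to compound 3 therefore cannot be sized. For the measured compounds named here, every value so far sits at the limit of > 30000 nM in this assay, at which 3 of the 3 values shown sit, so no measured step tells how much any change shifts potency.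

Compound 4 `COc1ccc(-c2nc(C(=O)/C=C\Nc3ccc(F)cc3)c3ccccn23)cc1` differs from compound 1 by methoxy in place of trifluoromethyl on an aromatic carbon. Going by the values given here, no measured step bears on this change, and the one step that involves a different group on the core is unreadable. With nothing pointing to a gain, compound 4 is expected to show a step that the limit leaves unreadable from compound 1 to compound 4, with a strong chance that only a limit is reported again. Compound 4 is thus estimated at 40000 nM, with a range from 12000 nM to 120000 nM.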

Compound 4, half-maximal inhibitory concentration: > 30000 nM
Compound 4: no number, only a limit (the forecaster's own chance of this, stated with the estimate: 80%); the middle value lies beyond the limit too.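

Compound 4 gives only a limit, as does compound 1, so the size of the change from trifluoromethyl to methoxy cannot be read from this pair. All the results stand at one limit: the limit of > 30000 nM in this assay, at which 4 of the 4 values shown sit.

The compounds shown leave open whether any change to the shared core brings a measurable potency in this assay at all.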